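Benzyl ether variation on a bis-aryloxyethylamine series

The source may hold more compounds than are shown below. What is called first, only, known or untested is meant among the compounds shown, and "the series" means these compounds.

Measured so far, in an assay on CHO cells for displacement of a labelled ligand from Alpha-1A adrenergic receptor (Homo sapiens); on this read-out higher numbers stand for weaker inhibition and lower numbers for stronger inhibition:
compound 1 `COc1cccc(OC)c1OCCNCCOc1ccccc1OCc1ccccc1C`, 1.59 nM
compound 2 `COc1cccc(OC)c1OCCNCCOc1ccccc1OCc1ccccc1[N+](=O)[O-]`, 7.94 nM

For the measured compounds named here, compound 2 gives the highest number of the two; its nearest neighbour is compound 1, with the step of a 5.0-fold higher number from compound 1 to compound 2 (0.70 log units; beyond the scatter), which is the only step recorded on the benzyl ring. Compound 3 `COc1ccc(COc2ccccc2OCCNCCOc2c(OC)cccc2OC)cc1` differs from compound 2 by 4-methoxyphenyl in place of 2-nitrophenyl on a saturated chain carbon bound to an oxygen on an aromatic ring, a change at the same ring as that step but of a different kind. Going by the values given here, the only available step was modest and runs from methyl to nitro; a methoxy group has no precedent here. For compound 3 a number between those of compounds 1 and 2 is expected, a 2.3-fold lower number from compound 2 to compound 3 (0.36 log units; beyond the scatter) in this assay, giving an estimate of 3.5 nM with a range from 1 nM to 12 nM.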

Compound 3, inhibition constant: 2 nM
Compound 3: middle estimate off by 1.8-fold (0.24 log units), on the high side; the range from low to high includes it.
By their numbers in this assay, from the lowest: compounds 1 and 3 (each within the scatter of the next); then compound 2.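

In this assay the change to 4-methoxyphenyl from 2-nitrophenyl gives a 4.0-fold lower number from compound 2 to compound 3 (0.60 log units; beyond the scatter) and the change from 2-methylphenyl gives a 1.3-fold higher number from compound 1 to compound 3 (0.10 log units; within the scatter) at this position. The 4-methoxyphenyl group therefore reads like the 2-methylphenyl group, and only the 2-nitrophenyl group of compound 2 stands apart. No supporting data bear on this difference.

Substituent identity and ring placement change together across these compounds, so neither can be read alone. Going by these compounds, how an unsubstituted phenyl, 2-methoxyphenyl, 4-nitrophenyl, or a ring carrying an amine or carboxylic acid would read remains open.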